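A Ring-Bearing Group on the Shared Core

A few compounds are considered here, and "the series" means these few. Any claim that something is new, unique, unknown or untested is made for them only; others in the source may bear on it.

Values in a functional assay with Oryctolagus cuniculus as the target; on this read-out lower numbers stand for stronger inhibition and higher numbers for weaker inhibition:
- compound 1 `COc1ccc(-c2nc(N=C(N)N)sc2-c2ccc(OC)cc2)cc1`: 31000 nM
- compound 2 `COc1ccc(-c2nc(/N=C(\N)N(C)C)sc2-c2ccc(OC)cc2)cc1`: 37 nM
- compound 3 `C/N=C(/NC)Nc1nc(-c2ccc(OC)cc2)c(-c2ccc(OC)cc2)s1`: 970 nM

Compound 3 holds the middle place among the three numbers. The gap to the lowest is a 26-fold higher number from compound 2 to compound 3 (1.42 log units; beyond the scatter), and the gap to the highest is a 32-fold lower number from compound 1 to compound 3 (1.50 log units; beyond the scatter). Both are large and beyond the scatter.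

The next compound, compound 4 `COc1ccc(-c2nc(/N=C(\N)N3CCOCC3)sc2-c2ccc(OC)cc2)cc1`, carries a group of 9 heavy atoms (5 carbon, 3 nitrogen, 1 oxygen; one six-membered non-aromatic ring with 2 hetero atoms) in place of a group of 6 heavy atoms (3 carbon, 3 nitrogen; no ring), on an aromatic carbon. Among the compounds with values here, the entering group contains one six-membered non-aromatic ring with 2 hetero atoms, and no compound measured so far has a ring in this group. Any forecast is therefore an extrapolation from three compounds.

Within the data shown here, three measured steps bear on it, all at this same place on the core. The first is an 840-fold lower number from compound 1 to compound 2 (2.92 log units; beyond the scatter), and the second is a 32-fold lower number from compound 1 to compound 3 (1.50 log units; beyond the scatter). The third, a 26-fold higher number from compound 2 to compound 3 (1.42 log units; beyond the scatter), shows that two groups of equal size can differ widely here. Among the measured compounds shown here, the group in compound 4 is built more like the one in compound 2 than the one in compound 3, so compound 4 is expected to lie nearer compound 2, though probably not to match it.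

In this assay, the expected change is an 8.1-fold lower number from compound 3 to compound 4 (0.91 log units; beyond the scatter), a moderate to large step. Compound 4 is estimated at 120 nM, with an expected range of 25 nM to 600 nM.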

Compound 4, half-maximal inhibitory concentration: < 1000 nM
Compound 4 gave a limit, no number; the forecaster's own chance of this, stated with the estimate: 3%; the middle value is on the limit's open side.
By their numbers in this assay, from the lowest: compound 2; then compound 3; then compound 1.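

Compound 4 gave a limit and not a number: the limit of < 1000 nM in this assay, at which 1 of the 4 values shown sits. Even so, the one step that can be read is an at least 31-fold lower number from compound 1 to compound 4 (1.49 log units; beyond the scatter), which shows for the first time that a group with a six-membered non-aromatic ring with 2 hetero atoms can stand at this place on the shared core and still keep compound 4 well clear of compound 1. The steps that link compound 4 to compound 2 and to compound 3 cannot be read, so the change of morpholin-4-yl in place of dimethylamino has no size yet, and compound 4 cannot be ranked against either of those two compounds.

The compounds shown leave open how far the ring can go in keeping the low numbers seen with dimethylamino, since a true value for compound 4 is missing. They also leave open what a piperidin-1-yl or pyrrolidin-1-yl group, with no ring oxygen, or an open-chain diethylamino group would give on the same carbon with a double bond to nitrogen, and so whether the ring itself or its oxygen matters at this place.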